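Trimethoxy lactam: expectation from two lactams at the limit

This account rests on a few compounds, and the source may have more. Where it says the series, first, only, none or still open, it means among the compounds named here.

Compound 3 `COc1ccc(/C=C/C2CC=CC(=O)N2)cc1OC` stands at a limit in a functional assay on 786-0 cells (Homo sapiens) for inhibition, read by sulforhodamine B assay, with a stated time of 48 h; a lower number here means a stronger inhibitor of growth, a higher number a weaker inhibitor of growth: compound 3 gives > 964 uM, a limit of the assay and not a number (the limit of > 964 uM in this assay, at which 1 of the 3 values shown sits). Compound 2 `COc1ccc(/C=C/C2CC=CC(=O)N2)cc1` likewise gives only a limit, > 1090 uM (the limit of > 1090 uM in this assay, at which 1 of the 3 values shown sits). Compound 1 `COc1cc(/C=C/C2CC=CC(=O)O2)cc(OC)c1OC`, the lactone, gives 18.5 uM in this assay. Compound 4 `COc1cc(/C=C/C2CC=CC(=O)N2)cc(OC)c1OC` differs from compound 3 as follows: methoxy in place of hydrogen on an aromatic carbon. Within the data shown here, the only measured step of this kind, a step that the two limits leave unreadable from compound 2 to compound 3, cannot be read for size, as both of its ends are limits. Among the measured compounds shown here, no measured step therefore supplies a direction for the change. The step to compound 4 is expected to be an at least 1.2-fold lower number from compound 3 to compound 4 (0.08 log units; that floor lies within the scatter), most likely again unreadable. The estimate for compound 4 in this assay is 800 uM, with a range from 200 uM to 3000 uM.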

Compound 4, concentration for growth inhibition (reported as GI): > 864 uM
Compound 4 ended at the assay's limit (the forecaster's own chance of this, stated with the estimate: 80%); at least 1.0-fold (0.03 log units) between middle value and limit.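

With methoxy in place of hydrogen on this aromatic carbon, compound 4 still stands at a limit in this assay: the limit of > 864 uM in this assay, at which 1 of the 4 values shown sits. The methoxy steps among the lactams cannot be read, so this position has no measurable effect size yet. Among these compounds, compound 4 does give the first comparison between lactone and lactam with the aromatic substitution held constant, and replacing the lactone with the lactam gives an at least 46-fold higher number from compound 1 to compound 4 (1.66 log units; beyond the scatter).

On these data alone, it remains open whether an amine or a chlorine atom at this aromatic carbon would bring a lactam to a readable value. Also open, as far as these compounds go, is how the lactone responds to fewer methoxy groups.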